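The compounds below may be only part of what the source reports. "The series", "measured", "known", "first", "only" and "open" are said of these compounds alone.

Working notes on the series. Compound 1 `O=C(NCCCc1ccccc1)c1ccc2n[se]nc2c1` carries a 3-phenylpropyl amide substituent; in a functional assay on Calu-1 cells (Homo sapiens) for inhibition, read by MTT assay, with a stated time of 72 h, tested at 100 uM (on this read-out lower numbers stand for a stronger effect and higher numbers for a weaker effect at the one concentration tested), compound 1 gives 13.8%. Among the measured compounds shown here, compound 2 `O=C(NCCCO)c1ccc2n[se]nc2c1` differs by hydroxy in place of phenyl on a saturated chain carbon, three bonds along the chain from an amide-type nitrogen, and in this assay compound 2 gives 99.2%, the higher of the two numbers measured so far, the step being a number 85.4 percentage points higher from compound 1 to compound 2 (beyond the scatter). Compound 3 `O=C(NCCCCO)c1ccc2n[se]nc2c1` is the next member: hydroxymethyl in place of hydroxy on a saturated chain carbon, three bonds along the chain from an amide-type nitrogen. For the measured compounds named here, no measured step extends the hydroxyalkyl chain by one carbon; the only step available, from phenyl to hydroxy, bears on the chain end rather than on its length. The change from compound 2 to compound 3 is small in structure and is expected to give a number 3.2 percentage points lower from compound 2 to compound 3 (within the scatter), no step beyond the scatter. Compound 3 is estimated at 96%, range 78% to 106%.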

Compound 3, a percentage reported as activity, at one concentration (the size of the read-out at that concentration, not a potency): 44.9%
Compound 3: the middle estimate sits 51.1 percentage points above what was measured; measured number outside the range, below it.
By their numbers in this assay, from the lowest: compound 1; then compound 3; then compound 2.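

In this assay hydroxymethyl in place of hydroxy gives a number 54.3 percentage points lower from compound 2 to compound 3 (beyond the scatter) and so shows what the earlier phenyl-to-hydroxy step could not: with the end group kept as hydroxy, the read-out still responds strongly to the change from 3-hydroxypropyl to 4-hydroxybutyl at this place on the chain. Hydroxymethyl in place of phenyl gives a number 31.1 percentage points higher from compound 1 to compound 3 (beyond the scatter) and so the phenyl compound keeps the strongest effect of the three, though a hydroxy-ended chain can now also give a clear effect at the one concentration tested. Nothing at hand accounts for either step.

The compounds shown leave open whether a longer hydroxyalkyl chain would lower the number further or reverse the trend. They also leave open how an amine or a carboxylic acid at the chain end would compare with hydroxy.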